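This account rests on a few compounds, and the source may have more. Where it says the series, first, only, none or still open, it means among the compounds named here.

The measured compounds and their values:
Compound 1, `O=C(NC1CCN(CC2CC2)C1)c1cc(-c2ccc(NS(=O)(=O)c3cccc(Cl)c3Cl)cc2)nc2[nH]ncc12`: 1 nM in an assay for inhibition of serine/threonine-protein kinase Sgk1 (Homo sapiens), with stated times of 30 min and 60 min, in the presence of a further agent that is not named here; a higher number here means a weaker inhibitor, a lower number a stronger inhibitor.
Compound 2, `CN1CC(NC(=O)c2cc(-c3ccc(NS(=O)(=O)c4cccc(Cl)c4Cl)cc3)nc3[nH]ncc23)C1`: < 1 nM in this assay, which is a limit of the assay.
Compound 3, `Cc1n[nH]c2nc(-c3ccc(NS(=O)(=O)c4cc(Cl)ccc4F)cc3)nc(OC3CCC(=O)CC3)c12`: 5 nM in this assay.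

Compound 3 carries the highest of the two numbers that are read as numbers; its nearest neighbour is compound 1, whose value lies lower by a gap beyond the usual scatter. Compound 2 stands at the limit of < 1 nM in this assay, at which 1 of the 3 values shown sits, so its distance from compound 3 is open. Going by the values given here, the one measured step, a number no higher from compound 1 to compound 2 (the limit leaves the size open), concerns the group on an amide-type nitrogen of a different core and gives a direction but no size.

Compound 4, `Cc1n[nH]c2nc(-c3ccc(NS(=O)(=O)c4cc(Cl)ccc4F)cc3)nc(OC3CC(C)(C)N(C)C(C)(C)C3)c12`, differs from compound 3 in one place: 1,2,2,6,6-pentamethylpiperidin-4-yl in place of 4-oxocyclohexyl on an oxygen on an aromatic ring. Among the compounds with values here, no measured step touches the group on the oxygen of the core of compound 3, so nothing here fixes the size of this change. The only step shown, from a carbon-only ring to a nitrogen-containing ring, was no higher from compound 1 to compound 2, and a similar mild drift is the most that can be expected in this assay. Compound 4 is therefore estimated at 4 nM, within 1.5 nM to 12 nM, which means an expected step of a 1.3-fold lower number from compound 3 to compound 4 (0.10 log units; within the scatter).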

Compound 4, half-maximal inhibitory concentration: 2 nM
Beside the measured number, compound 4's estimate is 2.0-fold (0.30 log units) above it; measured number inside the range.
By their numbers in this assay, from the lowest: compounds 1 and 4 (each within the scatter of the next); then compound 3.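

In this assay the exchange of 4-oxocyclohexyl for 1,2,2,6,6-pentamethylpiperidin-4-yl on this oxygen gives a 2.5-fold lower number from compound 3 to compound 4 (0.40 log units; beyond the scatter) and so gives the position its first measured step, modest in size. The earlier compounds shown here showed a change only on an amide-type nitrogen of a different core, whereas this result shows that, on the core of compound 3, a group of 11 heavy atoms with a ring nitrogen can replace one of 7 heavy atoms with a ring of carbon only, and the number does not rise. Nothing in the data shown accounts for the size or direction of this step.

The compounds shown leave open whether the step goes with the ring nitrogen or with the methyl groups around it, a question that a plain piperidin-4-yl or an unsubstituted cyclohexyl on the same oxygen would address. Also open, on these data alone, is how far the number would move with a morpholine-bearing chain or a carboxylic acid on this oxygen, and whether the same exchange would give a similar step on the core of compound 1.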